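This account rests on a few compounds, and the source may have more. Where it says the series, first, only, none or still open, it means among the compounds named here.

In a functional assay on HeLa cells (Homo sapiens), read by colorimetric assay, with a stated time of 72 h (on this read-out higher numbers stand for an effect only at larger amounts of compound and lower numbers for an effect already at smaller amounts), compound 1 (`CCOC(=O)c1cc(CBr)nn1[C@@H]1O[C@H](COC(C)=O)[C@@H](OC(C)=O)[C@H](OC(C)=O)[C@H]1OC(C)=O`) gives 5 ug/mL, compound 3 (`CC(=O)OC[C@H]1O[C@@H](n2nc(CBr)cc2C(N)=O)[C@H](OC(C)=O)[C@@H](OC(C)=O)[C@@H]1OC(C)=O`) gives 4 ug/mL and compound 2 (`CCOC(=O)c1cc(CBr)nn1[C@@H]1OC[C@@H](OC(C)=O)[C@@H](OC(C)=O)[C@H]1OC(C)=O`) gives 2 ug/mL. The number for compound 2 lies within the usual scatter of the number for compound 3, and it is lower than the number for compound 1 by more than that scatter. Compound 4 (`CC(=O)O[C@@H]1[C@H](OC(C)=O)[C@H](OC(C)=O)CO[C@H]1n1nc(CBr)cc1C(N)=O`) has not yet been measured. It departs from compound 2 by one exchange, amino in place of ethoxy on a carbonyl carbon, or ethoxycarbonyl to carbamoyl: amino in place of ethoxy on a carbonyl carbon. Within the data shown here, only one measured step bears on this exchange. It gave a 1.3-fold lower number from compound 1 to compound 3 (0.10 log units; within the scatter), which stays within the scatter, and it was seen on the core of compound 1, not on that of compound 2. On this single precedent, no change beyond the scatter is expected in this assay. The expected size is a 1.1-fold lower number from compound 2 to compound 4 (0.05 log units; within the scatter). Compound 4 is estimated at 1.8 ug/mL, with an expected range from 0.9 ug/mL to 4 ug/mL.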

Compound 4, concentration for half-maximal effect: 3 ug/mL
Compound 4: the middle estimate sits 1.7-fold (0.22 log units) below what was measured; measured number inside the range.
By their numbers in this assay, from the lowest: compounds 2, 4, 3 and 1 (each within the scatter of the next, the first and the last beyond it).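

In this assay, the exchange of ethoxy for amino on a carbonyl carbon now has a second reading, on a second core: a 1.5-fold higher number from compound 2 to compound 4 (0.18 log units; within the scatter). Neither reading leaves the scatter, and the two cores do not differ in their response to this change: the same change on two cores in this assay, a 1.3-fold lower number (0.10 log units; within the scatter) from compound 1 to compound 3 and a 1.5-fold higher number (0.18 log units; within the scatter) from compound 2 to compound 4, 1.9-fold (0.27 log units) apart, within the scatter of two such steps What had rested on the core of compound 1 alone now holds on both cores shown, so at this place ethoxycarbonyl and carbamoyl cannot be told apart in this assay.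

The compounds shown leave open whether another group on this carbonyl carbon, such as a carboxylic acid, an N-methyl amide or a longer ester chain, would move the number beyond the scatter. They also leave open whether the exchange would stay as silent in any other cell line.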